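The compounds below may be only part of what the source reports. "The series", "measured", "known", "first", "only" and "open" are said of these compounds alone.

Working notes on the series. Among the measured compounds shown here, compound 1 `CCc1nnc2c(C#N)c(N3CCC(c4ccccc4)CC3)ccn12` stands highest of the three numbers so far in a functional assay on CHO cells for positive allosteric modulation of metabotropic glutamate receptor 2 (Homo sapiens), read by GTPgammaS binding, with a stated time of 30 min (on this read-out lower numbers stand for an effect already at smaller amounts and higher numbers for an effect only at larger amounts of compound), where compound 1 gives 696 nM. For the measured compounds named here, compound 2 `CCCc1cnc2c(C#N)c(N3CCC(c4ccccc4)CC3)ccn12` gives 155 nM and compound 3 `N#Cc1c(N2CCC(c3ccccc3)CC2)ccn2c(CC(F)(F)F)cnc12` gives 125 nM; both differ from compound 1 in the core and in the chain at once, so no single step links them to compound 1. Compound 4 `N#Cc1c(N2CCC(c3ccccc3)CC2)ccn2c(CC3CC3)nnc12` carries cyclopropyl in place of methyl on a saturated chain carbon bound to an aromatic carbon. Going by the values given here, the one measured step on the chain, a 1.2-fold lower number from compound 2 to compound 3 (0.09 log units; within the scatter), lay within the scatter, and no measured step varies the chain on the core of compound 1. On that basis the step in this assay is expected to be small, a 1.4-fold lower number from compound 1 to compound 4 (0.14 log units; within the scatter), with no direction beyond the scatter. Compound 4 is therefore estimated at 500 nM, with a range of 200 nM to 1500 nM.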

Compound 4, half-maximal effective concentration: 74 nM
Estimate against measurement, compound 4: 6.8-fold (0.83 log units) above; the measured number lies below the stated range.
By their numbers in this assay, from the lowest: compounds 4, 3 and 2 (each within the scatter of the next, the first and the last beyond it); then compound 1.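

On the core of compound 1, the chain position responds in this assay to cyclopropyl in place of methyl on a saturated chain carbon bound to an aromatic carbon, with a 9.4-fold lower number from compound 1 to compound 4 (0.97 log units; beyond the scatter) as the step. Among the compounds shown here, the only earlier chain step, a 1.2-fold lower number from compound 2 to compound 3 (0.09 log units; within the scatter) on another core, gave no such sign. Nothing measured here bears on the reason for this step.

Open, going by these compounds, is whether a longer chain such as butyl, or a cyclobutyl ring, goes further on this core. Also open, on these data alone, is whether cyclopropyl gives a similar step on the core of compound 2.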